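Swapping a Protected Diol for a Sugar Ring

A few compounds are considered here, and "the series" means these few. Any claim that something is new, unique, unknown or untested is made for them only; others in the source may bear on it.

Compound 1 `CC1(C)O[C@@H](CO)[C@H](Cn2cc(Cn3c4c(c5ccccc53)C(=O)c3c[n+]([O-])c5ccccc5c3C4=O)nn2)O1` and compound 2 `O=C1c2c[n+]([O-])c3ccccc3c2C(=O)c2c1c1ccccc1n2CCCCN1CCNCC1` share the same core and have both been tested in a toxicity assay on HEK-293T cells (Homo sapiens) for cytotoxicity, read by MTT assay, with a stated time of 72 h; a lower number here means a stronger inhibitor, a higher number a weaker inhibitor. In that test compound 1 gives 120 nM, while compound 2 gives 760 nM. Compound 1 thus holds the lowest number of the two, and its gap to compound 2 is wider than repeat measurements usually scatter. Compound 3 `O=C1c2c[n+]([O-])c3ccccc3c2C(=O)c2c1c1ccccc1n2Cc1cn([C@@H]2O[C@H](CO)[C@@H](O)[C@H](O)[C@H]2O)nn1` is not yet measured. It differs from compound 1 in one place: 3,4,5-trihydroxy-6-(hydroxymethyl)oxan-2-yl in place of (5-(hydroxymethyl)-2,2-dimethyl-1,3-dioxolan-4-yl)methyl on an aromatic nitrogen. Going by the values given here, no measured pair shows what such a swap does on this core, so the expectation rests only on compound 1 and the size of the change. A modest weakening, no larger than the usual scatter or only slightly beyond it, seems most likely, and the estimated step is a 2.1-fold higher number from compound 1 to compound 3 (0.32 log units; beyond the scatter). Compound 3 is therefore expected to give about 250 nM in this assay, with a range from 80 nM to 800 nM.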

Compound 3, half-maximal inhibitory concentration: 940 nM
Compound 3: the middle estimate sits 3.8-fold (0.58 log units) below what was measured; measured number outside the range, above it.
By their numbers in this assay, from the lowest: compound 1; then compounds 2 and 3 (each within the scatter of the next).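

In this assay, putting 3,4,5-trihydroxy-6-(hydroxymethyl)oxan-2-yl in place of (5-(hydroxymethyl)-2,2-dimethyl-1,3-dioxolan-4-yl)methyl on the aromatic nitrogen gives a 7.8-fold higher number from compound 1 to compound 3 (0.89 log units; beyond the scatter), so the number in this test does respond to what this position carries. The two groups are close in heavy-atom count, but the entering group has more hydrogen-bond donors and acceptors, more defined stereocentres, and a six-membered ring in place of a five-membered one, so similar size did not mean a similar number here. Nothing measured explains the step.

Because all these features change in one swap, the compounds shown do not separate their contributions. As far as these compounds go, how a plain butyl chain or an amine would compare at this same position also remains open.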